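Fluoro for phenyl on the shared xanthine-type core

A few compounds are considered here, and "the series" means these few. Any claim that something is new, unique, unknown or untested is made for them only; others in the source may bear on it.

Measured so far:
- compound 1, `CCn1c(=O)c2nc(-c3cccc(S(=O)(=O)NCCN(C)C)c3)[nH]c2n(CC)c1=O`, 29.4 nM
- compound 2, `Cn1c(=O)c2nc(-c3ccccc3[N+](=O)[O-])[nH]c2n(C)c1=O`, 80 nM
- compound 3, `Cn1c(=O)c2nc(-c3ccc(-c4ccccc4)cc3)[nH]c2n(C)c1=O`, 3.5 nM

In an assay for binding affinity to adenosine receptor A1 (Bos taurus) (on this read-out higher numbers stand for weaker inhibition and lower numbers for stronger inhibition), compound 3 holds the lowest number of the three, beyond the scatter from both compound 1 and compound 2, so it is the strongest binder among the measured compounds. Compound 4, `Cn1c(=O)c2nc(-c3ccc(F)cc3)[nH]c2n(C)c1=O`, differs from compound 3 by one change: fluoro in place of phenyl on an aromatic carbon. Among the compounds with values here, no measured pair shows this change, so its effect is not known from the data. Since the large group is lost, a weaker binding is expected, with a step beyond the scatter. Compound 4 is therefore expected to give about 40 nM, between 10 nM and 160 nM, a step of an 11-fold higher number from compound 3 to compound 4 (1.06 log units; beyond the scatter).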

Compound 4, half-maximal inhibitory concentration: 3.5 nM
The estimate for compound 4 lay 11-fold (1.06 log units) above the measured number, outside the stated range (below it).
By their numbers in this assay, from the lowest: compounds 3 and 4 (each within the scatter of the next); then compound 1; then compound 2.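

Putting fluoro in place of phenyl on this aromatic carbon of the shared core leaves this assay with no change at the digits printed from compound 3 to compound 4 (within the scatter). The phenyl, with its six carbons and its ring, is therefore not needed to reach this number, and a single fluorine atom at the same place serves as well. Nothing in the data at hand accounts for the two groups reading alike.

Going by these compounds, it remains open whether a bare hydrogen, an amine or a carboxylic acid at this place would read the same. The compounds shown therefore cannot tell whether this position accepts almost any group or only some.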